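The compounds below may be only part of what the source reports. "The series", "measured", "known", "first", "only" and "open" are said of these compounds alone.

Of the two numbers gathered so far, compound 2 `COc1cc(N)c(Cl)cc1C(=O)CCC1CCN(CCNS(=O)(=O)c2cc(Br)ccc2Br)CC1` gives 16% in an assay on HEK293 cells for displacement of a labelled ligand from 5-hydroxytryptamine receptor 6 (Homo sapiens), with a stated time of 60 min, tested at 0.01 uM, in the presence of a further agent that is not named here (a higher number here means a stronger effect of the compound at the concentration tested, a lower number a weaker effect), and compound 1 `COc1cc(N)c(Cl)cc1C(=O)CCC1CCN(CCNS(=O)(=O)c2ccc(N)cc2)CC1` gives 7% in this assay, a gap that lies within the scatter. Compound 3 `COc1ccc(S(=O)(=O)NCCN2CCC(CCC(=O)c3cc(Cl)c(N)cc3OC)CC2)cc1` differs from compound 2 in one place: 4-methoxyphenyl in place of 2,5-dibromophenyl on a sulfonyl sulfur. Within the data shown here, the only measured step that bears on this change alters the same group on the sulfonyl sulfur: a number 9 percentage points higher from compound 1 to compound 2 (within the scatter). That step stayed within the scatter, so a step of similar size, a number 5 percentage points lower from compound 2 to compound 3 (within the scatter), is expected, with no clear direction. Compound 3 is therefore estimated at 11%, between 0% and 27%.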

Compound 3, a percentage reported as inhibition, at one concentration (the size of the read-out at that concentration, not a potency): 36%
Compound 3: the middle estimate sits 25 percentage points below what was measured, outside the stated range (above it).
By their numbers in this assay, from the lowest: compounds 1 and 2 (each within the scatter of the next); then compound 3.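

The group on the sulfonyl sulfur can move the read-out in this assay by more than the scatter: 4-methoxyphenyl in place of 2,5-dibromophenyl gives a number 20 percentage points higher from compound 2 to compound 3 (beyond the scatter) and methoxy in place of amino on an aromatic carbon gives a number 29 percentage points higher from compound 1 to compound 3 (beyond the scatter) on the same ring position. The earlier pair showed no such separation, whereas compound 3 now stands clear of both others.

As far as these compounds go, whether an ethoxy or a hydroxyl group in place of the methoxy would keep this higher number stays open. Nothing available here accounts for the rise.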